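A few compounds are considered here, and "the series" means these few. Any claim that something is new, unique, unknown or untested is made for them only; others in the source may bear on it.

The measured compounds:
Compound 1, `Cc1cc(C)cc(S(=O)(=O)c2c(C(=O)NC(C)C(=O)NCc3ccccc3F)[nH]c3ccc(Cl)cc23)c1`, gives 23300 nM in an ADME assay on MT4 cells (Homo sapiens) for cytotoxicity, read by MTT assay; on this read-out higher numbers stand for lower toxicity in this test and lower numbers for higher toxicity in this test.
Compound 2, `Cc1cc(C)cc(S(=O)(=O)c2c(C(=O)NC(C)C(=O)NCc3ccncc3)[nH]c3ccc(Cl)cc23)c1`, gives 19500 nM in this assay.
Compound 3, `Cc1cc(C)cc(S(=O)(=O)c2c(C(=O)NCc3n[nH]c4ccccc34)[nH]c3ccc(Cl)cc23)c1`, gives only a limit of the assay, > 50700 nM, in this assay.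

Compound 3 therefore stands at the edge of what this assay can report: the limit of > 50700 nM in this assay, at which 1 of the 3 values shown sits. Compound 1 and compound 2 sit at ordinary numbers. Compound 4, `Cc1cc(C)cc(S(=O)(=O)c2c(C(=O)NCC(=O)NCc3ccccc3F)[nH]c3ccc(Cl)cc23)c1`, is not yet measured. It differs from compound 3 by (2-fluorobenzyl)carbamoyl in place of 1H-indazol-3-yl on a saturated chain carbon bound to an amide-type nitrogen. This restores the (2-fluorobenzyl)carbamoyl group that compound 1 also carries. Going by the values given here, two measured steps bear on the question. a 1.2-fold lower number from compound 1 to compound 2 (0.08 log units; within the scatter). an at least 2.6-fold higher number from compound 2 to compound 3 (0.41 log units; beyond the scatter). The change from compound 3 to compound 4 largely runs that second step backwards, so a lower number, beyond the scatter, is expected: an at least 2.0-fold lower number from compound 3 to compound 4 (0.30 log units; that floor lies within the scatter). Compound 4 is expected to land near compound 1, at 25000 nM, with a likely range from 11000 nM to 55000 nM.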

Compound 4, half-maximal cytotoxic concentration: > 47300 nM
Compound 4 gave a limit, no number; the forecaster's own chance of this, stated with the estimate: 20%; middle value at least 1.8-fold (0.27 log units) away from the limit.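

With a limit for both compound 3 and compound 4, the step between them cannot be read, so the 1H-indazol-3-yl and (2-fluorobenzyl)carbamoyl groups cannot be ranked at this place in this assay. Still, the comparison with the pyridin-4-yl chain gives an at least 2.4-fold higher number from compound 2 to compound 4 (0.38 log units; beyond the scatter), which shows that a reading at the limit of this assay does not require the 1H-indazol-3-yl group. Hydrogen in place of methyl on the saturated chain carbon gives an at least 2.0-fold higher number from compound 1 to compound 4 (0.30 log units; that floor lies within the scatter), a first hint that this small change may matter, though the floor of that step does not settle it.

As far as these compounds go, the actual numbers behind the limits for compound 3 and compound 4 remain open. Also open, from the compounds shown here alone, is whether an ethyl group in place of that methyl would give a lower number than compound 1 does.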